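Changing the Amide Group in a Low-Cytotoxicity Set

A few compounds are considered here, and "the series" means these few. Any claim that something is new, unique, unknown or untested is made for them only; others in the source may bear on it.

In an ADME assay on MT4 cells (Homo sapiens) for cytotoxicity, read by MTT assay (a lower number here means that less compound is tolerated, a higher number that more compound is tolerated), compound 1 `Cc1ccc(NC(=O)CSc2nncnc2-c2cccc3ccccc23)c(Br)c1` gives 166000 nM, compound 2 `Cc1ccccc1NC(=O)CSc1nncnc1-c1cccc2ccccc12` gives 158000 nM, and compound 3 `O=C(CSc1nncnc1-c1ccccc1Cl)Nc1ccccn1` gives 172000 nM. Compound 2 therefore stands level with the other two, since its number lies within the scatter of both and cannot be ranked against them.

The next compound to be measured, compound 4 `O=C(CSc1nncnc1-c1cccc2ccccc12)Nc1cccnc1Cl`, differs from compound 2 in one place: 2-chloropyridin-3-yl in place of 2-methylphenyl on an amide-type nitrogen. Put simply, 2-chloropyridin-3-yl stands in place of 2-methylphenyl on an amide-type nitrogen.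

For the measured compounds named here, one measured step bears directly on this, as it also changes the group on that nitrogen: a 1.1-fold lower number from compound 1 to compound 2 (0.02 log units; within the scatter). That step is small and stays within the scatter. Compound 3 differs from compound 2 in more than one place, so it offers only loose support, although compound 3 at 172000 nM also stays within the scatter of compound 2. Going by the values given here, no measured step makes this exact exchange, so the evidence is thin and favours neither direction.

No change beyond the scatter is expected, and the estimated step is a 1.0-fold higher number from compound 2 to compound 4 (0.01 log units; within the scatter). For compound 4 the expected value is 160000 nM, with an estimated range of 85000 nM to 250000 nM.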

Compound 4, half-maximal cytotoxic concentration: 44000 nM
Compound 4: the middle estimate sits 3.6-fold (0.56 log units) above what was measured, outside the stated range (below it).
By their numbers in this assay, from the lowest: compound 4; then compounds 2, 1 and 3 (each within the scatter of the next).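

Up to this point the group on the amide-type nitrogen seemed free to change in this assay with little effect on the number, for the only step at this position was small (a 1.1-fold lower number from compound 1 to compound 2 (0.02 log units; within the scatter)). The exchange to 2-chloropyridin-3-yl shows that this position can move the number beyond the scatter: there is a 3.6-fold lower number from compound 2 to compound 4 (0.56 log units; beyond the scatter) and also a 3.8-fold lower number from compound 1 to compound 4 (0.58 log units; beyond the scatter), so less compound is tolerated whichever of the two phenyl groups leaves. Nothing measured here bears on why the number falls.

The new group differs from 2-methylphenyl both in its chlorine and in its ring nitrogen, so the compounds shown leave open which of these two changes goes with the lower number; a 2-chlorophenyl group and a plain pyridin-3-yl group on the same nitrogen would separate them. From the compounds shown here alone, it also remains open whether 2-chloropyridin-3-yl lowers the number to the same extent when the 2-chlorophenyl group of compound 3 replaces the larger ring system of the shared core.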